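A few compounds are considered here, and "the series" means these few. Any claim that something is new, unique, unknown or untested is made for them only; others in the source may bear on it.

Measured so far:
- Compound 1, `OC[C@]1(c2ccc(F)cc2)NC[C@H](O)[C@H]1O`: 101000 nM
- Compound 2, `COc1ccc([C@]2(CO)NC[C@@H](O)[C@@H]2O)cc1`: 395000 nM
- Compound 3, `CCCCCCCCC[C@]1(CO)NC[C@@H](O)[C@@H]1O`: 66000 nM

In an assay on isolated protein for inhibition of lysosomal alpha-glucosidase (Rattus norvegicus), read by colorimetric assay (a higher number here means a weaker inhibitor, a lower number a stronger inhibitor), compound 2 gives the highest of the three numbers, with compound 1 the nearest and compound 3 the furthest, both gaps lying beyond the usual scatter. Compound 4, `OC[C@@]1(c2ccc(O)cc2)NC[C@@H](O)[C@@H]1O`, has not yet been measured. It differs from compound 2 in one place: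

hydrogen in place of methyl on an oxygen on an aromatic ring

Among the measured compounds shown here, no measured pair shows this change, so its effect can only be expected. Since compound 2 sits at the weak end of the set, a modest step toward a lower number in this assay seems plausible for compound 4, yet a step within the scatter cannot be ruled out. Compound 4 is expected to give 200000 nM, within 60000 nM to 600000 nM, meaning an estimated step of a 2.0-fold lower number from compound 2 to compound 4 (0.30 log units; within the scatter).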

Compound 4, half-maximal inhibitory concentration: 11000 nM
Compound 4: middle estimate off by 18-fold (1.26 log units), on the high side, and the stated range ends above it.
By their numbers in this assay, from the lowest: compound 4; then compounds 3 and 1 (each within the scatter of the next); then compound 2.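

In this assay, among the compounds shown here, the change from methoxy to hydroxy gives a 36-fold lower number from compound 2 to compound 4 (1.56 log units; beyond the scatter) and is the first direct reading of this position. For the compounds shown here, removing one methyl from an oxygen on an aromatic ring is enough to move the number strongly, so what sits on this oxygen matters greatly, which the earlier compounds could not show. No measurement at hand explains why the step is so large. From the compounds shown here alone, whether an amine or a carboxylic acid in place of the hydroxy would keep the lower number remains open, as does what an ethoxy would do.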